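Ether to ester change on the shared core: cytotoxicity notes

A few compounds are considered here, and "the series" means these few. Any claim that something is new, unique, unknown or untested is made for them only; others in the source may bear on it.

Measured compounds:
compound 1 `C#CCOc1cc(/C=C/C(=O)c2ccc(OC)c3c2OC(C)(C)C=C3)ccc1OC`: > 10000 nM (a limit)
compound 2 `COc1ccc(/C=C/C(=O)c2ccc(OC)c3c2OC(C)(C)C=C3)cc1OCCCN(C)C`: 2920 nM

Going by the values given here, in a functional assay on K562 cells (Homo sapiens) for cytotoxicity, read by MTT assay (a higher number here means a weaker inhibitor, a lower number a stronger inhibitor), compound 2 gives 2920 nM and is the only compound with a number. For compound 1 the result > 10000 nM is a limit of the assay, not a number. Among the compounds with values here, the single measured step, an at least 3.4-fold lower number from compound 1 to compound 2 (0.53 log units; beyond the scatter), is therefore known only as a bound, see (the limit of > 10000 nM in this assay, at which 1 of the 2 values shown sits).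

Compound 3 `COc1ccc(/C=C/C(=O)c2ccc(OC)c3c2OC(C)(C)C=C3)cc1OC(=O)c1ccco1` carries the change ((furan-2-yl)carbonyl in place of 3-(dimethylamino)propyl on an oxygen on an aromatic ring). The step from compound 1 to compound 2 bears on it, since both changes sit on the same oxygen on an aromatic ring: there the entry of the 3-(dimethylamino)propyl chain brought the at least modest gain of an at least 3.4-fold lower number from compound 1 to compound 2 (0.53 log units; beyond the scatter). In compound 3 that chain leaves again and a (furan-2-yl)carbonyl enters, so part of that gain is expected to be given back, with a higher number likely, though the size is uncertain.

Compound 3 is estimated at 6000 nM (range 2500 nM to 15000 nM), a step of a 2.1-fold higher number from compound 2 to compound 3 (0.31 log units; beyond the scatter), with some chance of only a limit being reported.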

Compound 3, half-maximal inhibitory concentration: 450 nM
The estimate for compound 3 lay 13-fold (1.12 log units) above the measured number, outside the stated range (below it).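

In this assay, the oxygen on the aromatic ring does not need the 3-(dimethylamino)propyl chain for a low number: (furan-2-yl)carbonyl in its place gives a 6.5-fold lower number from compound 2 to compound 3 (0.81 log units; beyond the scatter), so an amine on this oxygen is not required, and an ester-linked ring does better than that ether-linked chain. Set against the propargyl ether, the same ester gives an at least 22-fold lower number from compound 1 to compound 3 (1.34 log units; beyond the scatter), though this step is only a bound: the limit of > 10000 nM in this assay, at which 1 of the 3 values shown sits. With all steps among the three compounds beyond the scatter, compound 3 is the strongest inhibitor shown, and the change of linkage and group at this one oxygen spans the whole range seen so far.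

The compounds shown leave open whether the gain belongs to the carbonyl link or to the furan ring, since both enter together in compound 3; an acetyl or benzoyl ester and a furan-2-ylmethyl ether on the same oxygen would pull the two apart. Also open, on these data alone, is how far the ring itself can vary, for example with a thiophene-2-carbonyl or pyridine-3-carbonyl group in place of (furan-2-yl)carbonyl.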